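Dropping the Chloro Group: Expected Effect on Growth Inhibition

The source may report more compounds than this note shows. Statements on the series, on what has been measured and on what is new or still open speak of the compounds shown alone.

Of the compounds shown here, three have been measured in a functional assay on T47D cells (Homo sapiens) for inhibition; a lower number here means a stronger inhibitor of growth, a higher number a weaker inhibitor of growth. Compound 1 `COc1cc(/C=C/C(=O)c2cccc(-n3cc(-c4ccc(Cl)cc4)[nH]c3=O)c2)ccc1O` gives 3090 nM, compound 2 `COc1cc(/C=C/C(=O)c2cccc(-n3cc(-c4ccccc4)[nH]c3=O)c2)ccc1O` gives 2700 nM, and compound 3 `O=C(/C=C/c1cccc(O)c1)c1cccc(-n2cc(-c3ccc(Cl)cc3)[nH]c2=O)c1` gives 1920 nM. Compound 3 thus shows the lowest of the three numbers, but its gaps to compound 2 and to compound 1 are both within the scatter, so the three cannot be ranked with any confidence.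

Compound 4 `O=C(/C=C/c1cccc(O)c1)c1cccc(-n2cc(-c3ccccc3)[nH]c2=O)c1` has not yet been measured in this assay. It differs from compound 3 in a single place: hydrogen in place of chloro on an aromatic carbon.

For the measured compounds named here, one measured step bears directly on this change. Between compound 1 and compound 2 the same chloro-to-hydrogen swap was made, and that step gave a 1.1-fold lower number from compound 1 to compound 2 (0.06 log units; within the scatter). The other measured step, a 1.6-fold lower number from compound 1 to compound 3 (0.21 log units; within the scatter), concerns a different part of the molecule and also stayed within the scatter.

Going by the values given here, the one comparable precedent showed no shift beyond the scatter. The expected step is therefore a 1.1-fold lower number from compound 3 to compound 4 (0.03 log units; within the scatter), a number that is essentially unchanged. In this assay compound 4 is estimated at 1800 nM, with a range from 900 nM to 3600 nM.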

Compound 4, concentration for 50% growth inhibition: 4240 nM
Estimate against measurement, compound 4: 2.4-fold (0.37 log units) below; the measured number lies above the stated range.
By their numbers in this assay, from the lowest: compounds 3, 2, 1 and 4 (each within the scatter of the next, the first and the last beyond it).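

Unlike either earlier step, the change from 4-chlorophenyl to phenyl now gives a shift beyond the scatter in this assay: a 2.2-fold higher number from compound 3 to compound 4 (0.34 log units; beyond the scatter). The chloro group para to a large group therefore matters to growth inhibition in at least one of the two compounds that carry it, but a dependence on the rest of the molecule cannot be claimed, as the gap between the two chloro-to-hydrogen steps stays within what two such steps can scatter: the same change on two cores in this assay, a 1.1-fold lower number (0.06 log units; within the scatter) from compound 1 to compound 2 and a 2.2-fold higher number (0.34 log units; beyond the scatter) from compound 3 to compound 4, 2.5-fold (0.40 log units) apart, within the scatter of two such steps The other change, 3-hydroxyphenyl in place of 4-hydroxy-3-methoxyphenyl, gives a 1.6-fold higher number from compound 2 to compound 4 (0.20 log units; within the scatter) on the compounds without chloro, and it too shows no clear dependence on what sits at the chloro position: the same change on two cores in this assay, a 1.6-fold lower number (0.21 log units; within the scatter) from compound 1 to compound 3 and a 1.6-fold higher number (0.20 log units; within the scatter) from compound 2 to compound 4, 2.5-fold (0.40 log units) apart, within the scatter of two such steps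

Going by these compounds, only chloro and hydrogen appear at this place on the ring, so whether the shift is particular to chloro or would also follow from a fluoro, a methoxy or an amine there remains open. On these data alone, with just two pairs for each change, it is also open whether the larger chloro-to-hydrogen step would recur on further cores.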